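The compounds below may be only part of what the source reports. "The series", "measured", "known", "first", "only" and "open" are said of these compounds alone.

Three close relatives have been measured so far in a functional assay on HL-60 cells (Homo sapiens) for cytotoxicity, with a stated time of 24 h; on this read-out higher numbers stand for lower toxicity in this test and lower numbers for higher toxicity in this test. Compound 1 `O=C1/C(=C/c2ccc(F)cc2)CCC/C1=C\c1cccc([N+](=O)[O-])c1` gives 1000 nM and compound 2 `Cc1ccc(/C=C2\CCC/C(=C\c3cccc([N+](=O)[O-])c3)C2=O)cc1` gives 38000 nM while compound 3 `O=C1/C(=C/c2ccccc2)CCC/C1=C\c1ccc([N+](=O)[O-])cc1` reads (20000 nM). Compound 3 therefore stands within the usual scatter of compound 2 and far higher than compound 1. Compound 4 `Cc1ccc(/C=C2\CCC/C(=C\c3ccc([N+](=O)[O-])cc3)C2=O)cc1` alters compound 3 in one place, with methyl in place of hydrogen on an aromatic carbon. Within the data shown here, the only measured step in which methyl enters is a 38-fold higher number from compound 1 to compound 2 (1.58 log units; beyond the scatter) which is large, yet there methyl replaces fluoro and not hydrogen. Among the measured compounds shown here, no measured step shows methyl replacing hydrogen, so only a modest rise is expected in this assay and nothing beyond the scatter. The expected step is a 1.4-fold higher number from compound 3 to compound 4 (0.15 log units; within the scatter) on this estimate. For compound 4 the estimated value is 28000 nM (expected range 9000 nM to 80000 nM).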

Compound 4, half-maximal cytotoxic concentration: 27000 nM
The estimate for compound 4 lay 1.0-fold (0.02 log units) above the measured number, within the range that was stated.
By their numbers in this assay, from the lowest: compound 1; then compounds 3, 4 and 2 (each within the scatter of the next).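

In this assay, the change from phenyl to 4-methylphenyl gives a 1.4-fold higher number from compound 3 to compound 4 (0.13 log units; within the scatter), so on this pair methyl in place of hydrogen shows no change beyond the scatter. The large 38-fold higher number from compound 1 to compound 2 (1.58 log units; beyond the scatter), where methyl replaces fluoro, therefore finds no match when methyl replaces hydrogen. No available evidence accounts for either step. Going by these compounds, it remains open whether fluoro at this place on compound 3 would give a much lower number, as in compound 1. An amine or a carboxylic acid at this place also remains untested among the compounds shown.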